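Replacing naphthalen-1-yl with 4-cyanophenyl in compound 2

The compounds below may be only part of what the source reports. "The series", "measured", "known", "first", "only" and "open" are said of these compounds alone.

- compound 1 `CC(C)[C@H](NC(=O)COc1cccc2ccccc12)C(=O)N[C@@H](CC(=O)O)C(=O)COC(=O)c1c(Cl)cccc1Cl` gives 11500 nM
- compound 2 `CC(C)[C@H](NC(=O)COc1cccc2ccccc12)C(=O)N[C@@H](CC(=O)O)C(=O)COc1cccc2ccccc12` gives 19000 nM
- compound 3 `CC(C)[C@H](NC(=O)COc1cccc2ccccc12)C(=O)N[C@@H](CC(=O)O)C(=O)COc1ccc(-c2ccccc2)cc1` gives 38700 nM

All three values come from a functional assay with Homo sapiens as the target; a higher number here means a weaker inhibitor, a lower number a stronger inhibitor. The two lowest values cannot be told apart, since the data show a 1.7-fold higher number from compound 1 to compound 2 (0.22 log units; within the scatter). Above them, the data show a 2.0-fold higher number from compound 2 to compound 3 (0.31 log units; beyond the scatter). Compound 2 therefore belongs to the lower pair of the three, and compound 3 is the weakest inhibitor of the series.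

Compound 4 `CC(C)[C@H](NC(=O)COc1cccc2ccccc12)C(=O)N[C@@H](CC(=O)O)C(=O)COc1ccc(C#N)cc1` has not yet been measured. Its difference is 4-cyanophenyl in place of naphthalen-1-yl on an oxygen on a saturated carbon, which in words is 4-cyanophenyl in place of naphthalen-1-yl on an oxygen on a saturated carbon.

For the measured compounds named here, no measured step makes this exact exchange, but three steps change the group at this same place. Besides the two above, the data show a 3.4-fold higher number from compound 1 to compound 3 (0.53 log units; beyond the scatter), the largest of the three and still modest. None of them points to a direction for a 4-cyanophenyl group, so only a small change is expected, and none beyond the scatter. The expected step is a 1.1-fold higher number from compound 2 to compound 4 (0.02 log units; within the scatter). For compound 4 the estimated value is 20000 nM. The expected range runs from 9000 nM to 45000 nM.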

Compound 4, half-maximal inhibitory concentration: 26700 nM
Beside the measured number, compound 4's estimate is 1.3-fold (0.13 log units) below it; low and high end bracket the measured number.
By their numbers in this assay, from the lowest: compounds 1, 2, 4 and 3 (each within the scatter of the next, the first and the last beyond it).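

In this assay, exchanging naphthalen-1-yl for 4-cyanophenyl on this oxygen replaces two six-membered aromatic rings with one and adds a triple bond and a hydrogen-bond acceptor, yet the number stays within the scatter (a 1.4-fold higher number from compound 2 to compound 4 (0.15 log units; within the scatter)). Cyano in place of phenyl on the aromatic carbon also stays within the scatter (a 1.4-fold lower number from compound 3 to compound 4 (0.16 log units; within the scatter)), so compound 4 cannot be told apart from either compound 2 or compound 3, even though those two are printed as just beyond the scatter of each other. Compound 4 is a modestly weaker inhibitor than compound 1 (a 2.3-fold higher number from compound 1 to compound 4 (0.37 log units; beyond the scatter)), which makes 4-cyanophenyl the second group on this oxygen, after 4-phenylphenyl, to stand beyond the scatter from the (2,6-dichlorophenyl)carbonyl group.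

Nothing in the material at hand accounts for these small differences. As far as these compounds go, it also remains open whether an amine or a carboxylic acid in place of cyano on the aromatic carbon would move the number outside this narrow band.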